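Swapping Fluoro for Nitro on a Formyl-Bearing Core

A few compounds are considered here, and "the series" means these few. Any claim that something is new, unique, unknown or untested is made for them only; others in the source may bear on it.

Within the data shown here, compound 3 `O=Cc1c(-c2ccc(F)cc2)nc2sc(Cc3ccc(Cl)cc3)nn12` gives 17000 nM in an ADME assay on CCRF-CEM cells (Homo sapiens) for cytotoxicity, with a stated time of 72 h (a lower number here means a stronger inhibitor, a higher number a weaker inhibitor), the only real number among the three measured compounds. Compound 1 `Fc1ccc(-c2cn3nc(Cc4ccc(Cl)cc4)sc3n2)cc1` reaches only the limit > 250000 nM in this assay. Compound 2 `Fc1ccc(-c2nc3sc(Cc4ccc(Cl)cc4)nn3c2Br)cc1` likewise stops at the limit > 250000 nM. The steps of an at least 14-fold lower number from compound 1 to compound 3 (1.16 log units; beyond the scatter) and an at least 14-fold lower number from compound 2 to compound 3 (1.16 log units; beyond the scatter) both concern the formyl group, which compound 4 `O=Cc1c(-c2ccc([N+](=O)[O-])cc2)nc2sc(Cc3ccc(Cl)cc3)nn12` keeps unchanged; the step that the two limits leave unreadable from compound 1 to compound 2 cannot be read. Among the measured compounds shown here, compound 4 differs from compound 3 by nitro in place of fluoro on an aromatic carbon, a change on the outer ring that none of the measured steps touches. Without any measured guidance for this change, the expected step is no change at the digits printed from compound 3 to compound 4 (within the scatter), none beyond the scatter. Compound 4 is therefore estimated at 17000 nM, with a range from 5000 nM to 60000 nM.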

Compound 4, half-maximal inhibitory concentration: 13000 nM
Compound 4: middle estimate off by 1.3-fold (0.12 log units), on the high side, and the stated range covers the measured number.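

At the para carbon of the outer ring, going from 4-fluorophenyl to 4-nitrophenyl gives a 1.3-fold lower number from compound 3 to compound 4 (0.12 log units; within the scatter) in this assay. Among these compounds, this is the first reading at this position, since the earlier steps all changed a different carbon of the core, and it shows that the fluoro and nitro compounds cannot be told apart here. Nothing measured here gives a reason for this result.

Going by these compounds, whether an amine, a carboxylic acid or a longer chain at this position would move the number stays open. So does whether the same swap would read alike without the formyl group.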